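The compounds below may be only part of what the source reports. "The series", "measured", "known", "first", "only" and "open" are said of these compounds alone.

Measured so far in a functional assay on HepG2 cells (Homo sapiens) for cytotoxicity, read by MTT assay, with a stated time of 72 h; on this read-out higher numbers stand for weaker inhibition and lower numbers for stronger inhibition:
- Compound 1 `COc1ccc(-n2cc(CCCOS(=O)(=O)c3ccc(C)cc3)nn2)cc1`: > 100000 nM (a limit of the assay, not a number)
- Compound 2 `Cc1ccc(S(=O)(=O)OCCCc2cn(-c3cccc(F)c3)nn2)cc1`: 61800 nM

Going by the values given here, compound 2 gives 61800 nM, the only actual number so far. The sole other result is the limit held by compound 1.

Compound 3 `Cc1ccc(-n2cc(CCCOS(=O)(=O)c3ccc(C)cc3)nn2)cc1` has not yet been measured. It has 4-methylphenyl in place of 3-fluorophenyl on an aromatic nitrogen.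

Among the compounds with values here, one measured step bears on this change, as it falls at the same place: an at least 1.6-fold lower number from compound 1 to compound 2 (0.20 log units; that floor lies within the scatter). Its size is only a floor, set by the limit of > 100000 nM in this assay, at which 1 of the 2 values shown sits. It exchanges 4-methoxyphenyl for 3-fluorophenyl, so it shows no clear effect of the group at that place in this assay.

No step beyond the scatter is therefore expected, and the expected change is a 1.1-fold higher number from compound 2 to compound 3 (0.05 log units; within the scatter). Compound 3 may also return only a limit. The expected value for compound 3 is 70000 nM, with an estimated range from 30000 nM to 130000 nM.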

Compound 3, half-maximal inhibitory concentration: > 100000 nM
Compound 3: only a limit was reported; the forecaster's own chance of this, stated with the estimate: 30%; middle value at least 1.4-fold (0.15 log units) from the limit.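

In this assay, compound 3 gives > 100000 nM, a limit of the assay and not a number. Placing 4-methylphenyl instead of 3-fluorophenyl on the aromatic nitrogen gives an at least 1.6-fold higher number from compound 2 to compound 3 (0.20 log units; that floor lies within the scatter), so this change, like the earlier exchange at the same place, shows no clear effect of the group and does not separate 4-methylphenyl from 3-fluorophenyl. The step of methyl in place of methoxy on the aromatic carbon cannot be read, and the true size of any change at this position stays hidden, because most of the series now sits at the assay's ceiling: the limit of > 100000 nM in this assay, at which 2 of the 3 values shown sit.

The compounds shown leave open whether any group at this place can move the number beyond the scatter, for instance a phenyl ring carrying an amine or a carboxylic acid. Also open, on these data alone, is whether a longer chain in the shared core would give a readable change.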